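The source may hold more compounds than are shown below. What is called first, only, known or untested is meant among the compounds shown, and "the series" means these compounds.

Compound 1 `O=C1N[C@@H](C(=O)O)C[Se]1`: > 3000000 nM (a limit)
Compound 2 `O=C(O)[C@@H]1C[Se]CN1`: 317000 nM

Among the compounds with values here, in a functional assay on V79 cells (Cricetulus griseus) for cytotoxicity (on this read-out higher numbers stand for weaker inhibition and lower numbers for stronger inhibition), compound 2 gives 317000 nM, the only actual number so far. Compound 1 is reported only as a limit, > 3000000 nM.

Compound 3 `CC1N[C@H](C(=O)O)C[Se]1` follows from compound 2 by placing methyl in place of hydrogen on a saturated ring carbon, next to the ring nitrogen and next to the ring selenium (methyl in place of hydrogen on a saturated ring carbon). Within the data shown here, no measured step shows what such a change does here, so the expected 1.1-fold lower number from compound 2 to compound 3 (0.02 log units; within the scatter) is none beyond the usual scatter. For compound 3 the estimated value is 300000 nM, with an expected range from 100000 nM to 1000000 nM.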

Compound 3, half-maximal inhibitory concentration: 79000 nM
Compound 3: the middle estimate sits 3.8-fold (0.58 log units) above what was measured; the whole stated range lies above it.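

In this assay, within the data shown here, methyl in place of hydrogen on the saturated ring carbon next to the ring nitrogen and next to the ring selenium gives a 4.0-fold lower number from compound 2 to compound 3 (0.60 log units; beyond the scatter), the first measured change at this position. A single added carbon there is thus enough to shift the read-out toward stronger inhibition, though only modestly. Nothing shown accounts for this shift. From the compounds shown here alone, whether ethyl, a longer chain or a carboxylic acid on this ring carbon would move the number further, or reverse it, remains open.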